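A few compounds are considered here, and "the series" means these few. Any claim that something is new, unique, unknown or untested is made for them only; others in the source may bear on it.

The measured compounds, in a functional assay on M21 cells (Homo sapiens) for antiproliferative activity, with a stated time of 48 h; on this read-out higher numbers stand for weaker inhibition and lower numbers for stronger inhibition:

Compound 1, `CCCCC(O)c1cccc(NC(=O)NC(=O)CCl)c1`, gives 4600 nM.
Compound 2, `CCCCC(OC)c1cccc(NC(=O)NC(=O)CCl)c1`, gives 4200 nM.
Compound 3, `CCCCC(O)c1cccc(NC(=O)NC(=O)CC)c1`, gives only a limit of the assay, > 100000 nM.

Compound 1 and compound 2 differ by a single change, (methyl in place of hydrogen on an oxygen on a saturated carbon). This change gave a 1.1-fold lower number from compound 1 to compound 2 (0.04 log units; within the scatter), so the two compounds cannot be told apart on this read-out. Compound 1 and compound 3 differ in their cores by methyl in place of chloro on a saturated chain carbon bound to a carbonyl carbon, and that change gave an at least 21-fold higher number from compound 1 to compound 3 (1.33 log units; beyond the scatter). The value for compound 3 is a limit and not a number, (the limit of > 100000 nM in this assay, at which 1 of the 3 values shown sits).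

Compound 4, `CCCCC(OC)c1cccc(NC(=O)NC(=O)CC)c1`, is not yet measured. It differs from compound 3 by methyl in place of hydrogen on an oxygen on a saturated carbon, which is the same change as from compound 1 to compound 2, at the same place. The expected step is therefore small, a step that the limit leaves unreadable from compound 3 to compound 4, resting on the earlier step of a 1.1-fold lower number from compound 1 to compound 2 (0.04 log units; within the scatter). Since compound 3 already sits at the limit, compound 4 is expected to come out near 150000 nM, most likely again reported only as a limit, within a range from 60000 nM to 400000 nM.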

Compound 4, half-maximal inhibitory concentration: > 100000 nM
Compound 4 gave a limit, no number (the forecaster's own chance of this, stated with the estimate: 80%); the middle value lies beyond the limit too.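

In this assay, methyl in place of chloro on the saturated chain carbon bound to a carbonyl carbon gave an at least 23-fold higher number from compound 2 to compound 4 (1.37 log units; beyond the scatter), so the large loss of inhibition first seen with the 1-hydroxypentyl group also appears with the 1-methoxypentyl group. In both pairs the direction is the same, and the change carries over from one core to the other in that sense: the same change on two cores in this assay, an at least 21-fold higher number (1.33 log units; beyond the scatter) from compound 1 to compound 3 and an at least 23-fold higher number (1.37 log units; beyond the scatter) from compound 2 to compound 4; the limit leaves it open whether they differ. What this does not show is whether the loss has the same size on both cores, and the step from compound 3 to compound 4 cannot be read either, as the results for these two compounds are limits and not numbers: the limit of > 100000 nM in this assay, at which 2 of the 4 values shown sit.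

The compounds shown leave open whether another group on that chain carbon, such as bromo or fluoro, would give a measurable value in this read-out. They also leave open how an amine in place of the hydroxy group, or a longer chain in place of the 1-hydroxypentyl group, would read.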